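Swapping chloro for trifluoromethyl on the phenyl of compound 3

The source may hold more compounds than are shown below. What is called first, only, known or untested is meant among the compounds shown, and "the series" means these compounds.

Measured compounds:
compound 1, `Cc1nc(-c2cccs2)sc1COc1ccc2c(c1)OCC2CC(=O)O`, 35.2%
compound 2, `Cc1nc(-c2ccccc2Cl)sc1COc1ccc2c(c1)OCC2CC(=O)O`, 12.4%
compound 3, `Cc1nc(-c2cccc(Cl)c2)sc1COc1ccc2c(c1)OCC2CC(=O)O`, 43%

All three share one core and differ only in the aromatic group attached to it. In a functional assay on CHO cells for agonist activity at Free fatty acid receptor 1 (Homo sapiens), read by FLIPR and calcium flux, tested at 100 nM (on this read-out lower numbers stand for a weaker effect and higher numbers for a stronger effect at the one concentration tested), compound 3 gives the highest of the three numbers. Compound 1 stands close to it, a number 7.8 percentage points higher from compound 1 to compound 3 (within the scatter), so the two cannot be told apart. Compound 2 lies clearly lower, a number 30.6 percentage points higher from compound 2 to compound 3 (beyond the scatter), and a number 22.8 percentage points lower from compound 1 to compound 2 (beyond the scatter) points the same way.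

Compound 4, `Cc1nc(-c2cccc(C(F)(F)F)c2)sc1COc1ccc2c(c1)OCC2CC(=O)O`, is compound 3 with one change: trifluoromethyl in place of chloro on an aromatic carbon. Going by the values given here, none of the measured steps swaps one group for another at the same place on the phenyl; the two large steps above concern where a chloro sits, not what sits there. Among the compounds with values here, the one step that keeps the place fixed and changes the group, from compound 1 to compound 3, stayed within the scatter. With nothing in the data pointing up or down, the expected step of a number 3 percentage points lower from compound 3 to compound 4 (within the scatter) in this assay is one that does not go beyond the scatter, and compound 4 is estimated at 40%, within 20% to 60%.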

Compound 4, a percentage reported as activity, at one concentration (the size of the read-out at that concentration, not a potency): 35.7%
For compound 4 the middle estimate is 4.3 percentage points above the measured one, and the stated range covers the measured number.
By their numbers in this assay, from the lowest: compound 2; then compounds 1, 4 and 3 (each within the scatter of the next).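

In this assay, going by these compounds alone, this is the first swap of one group for another at a fixed place on the phenyl, and trifluoromethyl, with its 4 heavy atoms, replaces chloro, with its 1 heavy atom, in a step of a number 7.3 percentage points lower from compound 3 to compound 4 (within the scatter). The new compound also cannot be told apart from the thiophen-2-yl compound, with a step of a number 0.5 percentage points higher from compound 1 to compound 4 (within the scatter), while it stands clear of the 2-chlorophenyl compound, with a step of a number 23.3 percentage points higher from compound 2 to compound 4 (beyond the scatter), so among these four compounds only compound 2 separates from the rest. Nothing measured here explains why the numbers fall this way.

Still open, from the compounds shown here alone, is whether a group of another kind at the place held by chloro in compound 3, such as an amine, a carboxylic acid or a longer chain like butoxy, would stay level with these compounds or separate from them. Also open, going by these compounds, is whether the low number of compound 2 belongs to chloro alone or would return with trifluoromethyl in 2-(trifluoromethyl)phenyl.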